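The source may hold more compounds than are shown below. What is called first, only, known or untested is meant among the compounds shown, and "the series" means these compounds.

Measured so far:
compound 1 `O=C(O)Cc1sc(C(c2ccccc2)c2ccc(F)cc2)nc1-c1ccc(Cl)cc1` — 17 nM
compound 2 `O=C(O)Cc1sc(C(c2ccc(F)cc2)c2ccc(F)cc2)nc1-c1cc(F)cc(F)c1` — 35 nM

In an in vitro assay on HEK385-7 cells for displacement of a labelled ligand from prostaglandin D2 receptor 2 (Homo sapiens) (a lower number here means a stronger inhibitor, a higher number a weaker inhibitor), compound 1 gives 17 nM and compound 2 gives 35 nM. Of the two numbers compound 2 has the higher one; its gap to compound 1 lies beyond the usual scatter. Compound 3 `O=C(O)Cc1sc(C(c2ccc(F)cc2)c2ccc(F)cc2)nc1-c1ccnc(F)c1` differs from compound 2 in one place: 2-fluoropyridin-4-yl in place of 3,5-difluorophenyl on an aromatic carbon. For the measured compounds named here, no step between measured compounds covers an exchange of this kind, so the expectation rests on compound 2 alone. The step of a 1.6-fold higher number from compound 2 to compound 3 (0.20 log units; within the scatter) is expected to be small, toward a higher number, at about the edge of the scatter. Compound 3 is expected to give roughly 55 nM, within 18 nM to 170 nM.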

Compound 3, half-maximal inhibitory concentration: 0.48 nM
Compound 3: the middle estimate sits 110-fold (2.06 log units) above what was measured; measured number below the stated range.
By their numbers in this assay, from the lowest: compound 3; then compound 1; then compound 2.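

In this assay, for the compounds shown here, 2-fluoropyridin-4-yl in place of 3,5-difluorophenyl on this aromatic carbon of the five-membered ring gives a 73-fold lower number from compound 2 to compound 3 (1.86 log units; beyond the scatter) and places compound 3 lowest of the series so far. The position therefore responds strongly to the exchange of one six-membered aromatic ring for another, with a ring nitrogen and one hydrogen-bond acceptor entering and one fluorine leaving. Nothing at hand accounts for the size of this step.

The compounds shown leave open how much of the step goes with the ring nitrogen and how much with the fluorine that leaves. A pyridin-4-yl or a 3-fluorophenyl on this carbon would separate the two.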